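Hydroxy on the benzimidazole and a swap of the terminal aryl

This account rests on a few compounds, and the source may have more. Where it says the series, first, only, none or still open, it means among the compounds named here.

Measured compounds:
Compound 1, `CN(C)c1ccc(-c2ccc(-c3ccc(-c4nc5ccccc5[nH]4)cc3)cc2)cc1`: 100000 nM
Compound 2, `Clc1cccc(-c2ccc(-c3ccc(-c4nc5ccccc5[nH]4)cc3)cc2)c1`: 100000 nM
Compound 3, `CN(C)c1ccc(-c2ccc(-c3ccc(-c4nc5c(O)cccc5[nH]4)cc3)cc2)cc1`: 9210 nM

In a functional assay on DWD cells (Homo sapiens) for inhibition, read by sulforhodamine B assay (a higher number here means a weaker inhibitor of growth, a lower number a stronger inhibitor of growth), compound 1 gives 100000 nM and compound 2 gives 100000 nM. Between them the step is no change at the digits printed from compound 1 to compound 2 (within the scatter), the change being (3-chlorophenyl in place of 4-(dimethylamino)phenyl on an aromatic carbon). Compound 3 differs from compound 1 in the core, (hydroxy in place of hydrogen on an aromatic carbon), and in this assay compound 3 gives 9210 nM, a step of an 11-fold lower number from compound 1 to compound 3 (1.04 log units; beyond the scatter).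

Compound 4, `Oc1cccc2[nH]c(-c3ccc(-c4ccc(-c5cccc(Cl)c5)cc4)cc3)nc12`, has not been measured. It stands to compound 3 as compound 2 stands to compound 1: the change is 3-chlorophenyl in place of 4-(dimethylamino)phenyl on an aromatic carbon, the same change already seen once, since the place is the same. That earlier step was no change at the digits printed from compound 1 to compound 2 (within the scatter). Among the measured compounds shown here, the same change on the core of compound 3 is expected to give a step of about a 1.3-fold higher number from compound 3 to compound 4 (0.11 log units; within the scatter), resting on the absence of movement from compound 1 to compound 2, with the caution that only one prior pair supports this. Compound 4 is therefore estimated at 12000 nM, within 4000 nM to 45000 nM.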

Compound 4, concentration for 50% growth inhibition: 2100 nM
Compound 4: the middle estimate sits 5.7-fold (0.76 log units) above what was measured, outside the stated range (below it).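

In this assay, putting 3-chlorophenyl in place of 4-(dimethylamino)phenyl on the hydroxy-bearing core gives a 4.4-fold lower number from compound 3 to compound 4 (0.64 log units; beyond the scatter), so this change did not carry over unaltered from the core without the hydroxy: the same change on two cores in this assay, no change at the digits printed (within the scatter) from compound 1 to compound 2 and a 4.4-fold lower number (0.64 log units; beyond the scatter) from compound 3 to compound 4, 4.4-fold (0.64 log units) apart, beyond the scatter of two such steps. Seen from the other side, adding the hydroxy to the 3-chlorophenyl compound gives a 48-fold lower number from compound 2 to compound 4 (1.68 log units; beyond the scatter), which has the same direction as the step on the 4-(dimethylamino)phenyl compound but is larger: the same change on two cores in this assay, an 11-fold lower number (1.04 log units; beyond the scatter) from compound 1 to compound 3 and a 48-fold lower number (1.68 log units; beyond the scatter) from compound 2 to compound 4, 4.4-fold (0.64 log units) apart, beyond the scatter of two such steps. The two changes therefore do not add independently in these four compounds, but a single set of four cannot show whether this holds across the series, nor why the steps differ.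

The compounds shown leave open whether a methoxy group or an amine in place of the hydroxy would produce a similar gain. They also leave open whether a fluorine or a nitrile in place of the chlorine would keep the lower number seen for compound 4.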